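A few compounds are considered here, and "the series" means these few. Any claim that something is new, unique, unknown or untested is made for them only; others in the source may bear on it.

Three compounds share one core and differ only in the group attached to the amide nitrogen. Compound 1 `COc1cc2cc(C(=O)NCc3ccc(F)cc3)c(=O)oc2cc1OCCCOc1no[n+]([O-])c1S(=O)(=O)c1ccccc1` gives 770 nM in a functional assay on MDA-MB-231 cells (Homo sapiens) for inhibition, read by MTT assay, with a stated time of 48 h; on this read-out lower numbers stand for stronger inhibition and higher numbers for weaker inhibition. Compound 2 `COc1ccc(CNC(=O)c2cc3cc(OC)c(OCCCOc4no[n+]([O-])c4S(=O)(=O)c4ccccc4)cc3oc2=O)cc1` gives 780 nM in this assay, and compound 3 `COc1cc2cc(C(=O)NCCCc3ccccc3)c(=O)oc2cc1OCCCOc1no[n+]([O-])c1S(=O)(=O)c1ccccc1` gives 760 nM. The three numbers sit close together: the step of a 1.0-fold lower number from compound 1 to compound 3 (0.01 log units; within the scatter) and the step of a 1.0-fold lower number from compound 2 to compound 3 (0.01 log units; within the scatter) are both within the scatter, as is the step of a 1.0-fold higher number from compound 1 to compound 2 (0.01 log units; within the scatter), so compound 3 stands level with the other two rather than apart from them.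

Compound 4 `COc1cc2cc(C(=O)NCCCc3ccc(F)cc3)c(=O)oc2cc1OCCCOc1no[n+]([O-])c1S(=O)(=O)c1ccccc1` is the next member, made from compound 3 by one change: fluoro in place of hydrogen on an aromatic carbon. The relevant comparisons already made are the swap of fluoro for methoxy between compound 1 and compound 2 and the removal of a para group with a change of chain between compound 1 and compound 3, and neither moved the number beyond the scatter. The step from compound 3 to compound 4 is therefore expected to be no change at the digits printed from compound 3 to compound 4 (within the scatter), with no change beyond the scatter. The estimate for compound 4 is 760 nM, in the range from 400 nM to 1450 nM.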

Compound 4, half-maximal inhibitory concentration: 690 nM
Beside the measured number, compound 4's estimate is 1.1-fold (0.04 log units) above it; the measured number falls inside the stated range.
By their numbers in this assay, from the lowest: compounds 4, 3, 1 and 2 (each within the scatter of the next).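

Among the compounds shown here, the step of a 1.1-fold lower number from compound 3 to compound 4 (0.04 log units; within the scatter) in this assay is the first direct test of fluoro against hydrogen on this ring, at the carbon para to a large group, since the earlier pairs only set fluoro against methoxy or changed the chain as well. A single fluorine added here leaves the number level, so this position accepts the change without a shift that can be told from scatter. The steps of a 1.1-fold lower number from compound 2 to compound 4 (0.05 log units; within the scatter) and a 1.1-fold lower number from compound 1 to compound 4 (0.05 log units; within the scatter) show that compound 4 also stands level with the other two, which leaves all four compounds together.

The compounds shown leave open whether an amine or a carboxylic acid on this ring, or a longer chain to the amide nitrogen, would move the number beyond the scatter. Nothing given here offers a reason for how level these numbers are.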